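Swapping fluoro for chloro in a small compound series

The compounds below may be only part of what the source reports. "The series", "measured", "known", "first", "only" and "open" are said of these compounds alone.

Compound 1 `COc1ccc(SCc2ccc(C(=O)Nc3ccccc3N)cc2)cc1` gives 90.1%
Compound 2 `CCc1ccc(SCc2ccc(C(=O)Nc3ccccc3N)cc2)cc1` gives 79.1%
Compound 3 `Nc1ccccc1NC(=O)c1ccc(CSc2ccc(F)cc2)cc1` gives 90.6%

Among the measured compounds shown here, these values come from a functional assay on HCT-116 cells (Homo sapiens) for inhibition, read by CCK-8 assay, with a stated time of 72 h, tested at 8 uM (on this read-out lower numbers stand for less inhibition of growth and higher numbers for more inhibition of growth at the one concentration tested), and the three compounds differ in only one group on an aromatic ring. Compound 3 shares the top of this small set. The gaps that place it there are a number 0.5 percentage points higher from compound 1 to compound 3 (within the scatter) and a number 11.5 percentage points higher from compound 2 to compound 3 (beyond the scatter) in the two comparisons.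

The next change leads to compound 4 `Nc1ccccc1NC(=O)c1ccc(CSc2ccc(Cl)cc2)cc1` and is counted as chloro in place of fluoro on an aromatic carbon in the structures: chloro in place of fluoro on an aromatic carbon, para to a large group.

For the measured compounds named here, no measured step involves chloro, so the evidence is indirect. The nearest guide is the set of swaps at this same place, which gave a number 0.5 percentage points higher from compound 1 to compound 3 (within the scatter) for fluoro in place of methoxy, a number 11 percentage points lower from compound 1 to compound 2 (beyond the scatter) for ethyl in place of methoxy, and a number 11.5 percentage points higher from compound 2 to compound 3 (beyond the scatter) for fluoro in place of ethyl. None of these swaps was large, so only a small shift is expected, most likely slightly downward and within the scatter. The expected step is a number 3.6 percentage points lower from compound 3 to compound 4 (within the scatter) on this estimate. In this assay compound 4 is expected at 87% with an estimated range from 76% to 95% as its likely span.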

Compound 4, percent growth inhibition at one concentration: 76.6%
Beside the measured number, compound 4's estimate is 10.4 percentage points above it, within the range that was stated.
By their numbers in this assay, from the lowest: compounds 4 and 2 (each within the scatter of the next); then compounds 1 and 3 (each within the scatter of the next).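

In this assay this place on the ring proves sensitive to a swap of one halogen for another: chloro in place of fluoro gives a number 14 percentage points lower from compound 3 to compound 4 (beyond the scatter) and shows that these two halogens cannot be treated as interchangeable here. Set against the other two groups, chloro gives a number 13.5 percentage points lower from compound 1 to compound 4 (beyond the scatter) when it replaces methoxy and a number 2.5 percentage points lower from compound 2 to compound 4 (within the scatter) when it replaces ethyl, so among these four compounds chloro sits with ethyl, while fluoro sits with methoxy. Nothing available explains why the two halogens part in this way.

Going by these compounds, whether bromo, an amine or a nitrile at this same place would fall with the fluoro and methoxy pair or with the chloro and ethyl pair remains open. Also open, on these data alone, is whether the gap between 4-fluorophenyl and 4-chlorophenyl would hold on a different core or at other concentrations, since a reading at one concentration gives no full dose-response picture.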